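This account rests on a few compounds, and the source may have more. Where it says the series, first, only, none or still open, it means among the compounds named here.

Working notes on the series: the shared core stays fixed and the aryl group on an amide-type nitrogen changes. In a functional assay on RT-112 cells (Homo sapiens) for antiproliferative activity, read by MTT assay, with a stated time of 72 h (a lower number here means a stronger inhibitor of growth, a higher number a weaker inhibitor of growth), compound 1 `COc1cc(Nc2ncnc3c(NC(=O)Nc4cc(Cl)cc(Cl)c4)cccc23)cc(OC)c1` gives 30.2 nM. Compound 2 `COc1cc(Nc2ncnc3c(NC(=O)Nc4cc(Cl)c(Cl)cc4Cl)cccc23)cc(OC)c1` gives 4890 nM, with a 160-fold higher number from compound 1 to compound 2 (2.21 log units; beyond the scatter). Compound 3 `COc1cc(Nc2ncnc3c(NC(=O)Nc4ccc([N+](=O)[O-])cc4)cccc23)cc(OC)c1` stands at > 20000 nM, which is a limit of the assay and not a number.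

Compound 4 `COc1cc(Nc2ncnc3c(NC(=O)Nc4cc(C)cc(C)c4)cccc23)cc(OC)c1` brings 3,5-dimethylphenyl in place of 4-nitrophenyl on an amide-type nitrogen.

Two measured steps end on the group that leaves here. Exchanging 3,5-dichlorophenyl for 4-nitrophenyl came with an at least 660-fold higher number from compound 1 to compound 3 (2.82 log units; beyond the scatter), a large step. Exchanging 2,4,5-trichlorophenyl for 4-nitrophenyl came with an at least 4.0-fold higher number from compound 2 to compound 3 (0.61 log units; beyond the scatter), at least modest. Read backwards, the first is the nearer guide, so a large fall in the number is expected in this assay. No methyl-bearing group has been measured yet, so the expectation stops short of the value of compound 1 at 30.2 nM.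

The expected step is an at least 100-fold lower number from compound 3 to compound 4 (2.00 log units; beyond the scatter). The estimate for compound 4 is 200 nM, with an expected range from 30 nM to 2500 nM.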

Compound 4, concentration for 50% growth inhibition: 10100 nM
Compound 4: the middle estimate sits 51-fold (1.70 log units) below what was measured; measured number above the stated range.
By their numbers in this assay, from the lowest: compound 1; then compound 2; then compound 4. At a limit, above all of these: compound 3.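

In this assay, 3,5-dimethylphenyl in place of 3,5-dichlorophenyl gives a 330-fold higher number from compound 1 to compound 4 (2.52 log units; beyond the scatter), so this exchange does not preserve the low number of compound 1. Set against 2,4,5-trichlorophenyl, 3,5-dimethylphenyl gives a 2.1-fold higher number from compound 2 to compound 4 (0.32 log units; beyond the scatter), and set against 4-nitrophenyl it gives an at least 1.9-fold lower number from compound 3 to compound 4 (0.29 log units; that floor lies within the scatter), a step whose floor lies within the scatter. The value of compound 3 is a limit of the assay and not a number: the limit of > 20000 nM in this assay, at which 1 of the 4 values shown sits.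

Among the groups shown, only 3,5-dichlorophenyl gives a number this low, so it remains open whether chloro itself is what matters at this position. 3,5-Dibromophenyl, 3,5-difluorophenyl, 3,5-bis(trifluoromethyl)phenyl and singly substituted 3-chlorophenyl on the same amide-type nitrogen would address that question.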